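This account rests on a few compounds, and the source may have more. Where it says the series, first, only, none or still open, it means among the compounds named here.

Measured so far in an assay on isolated protein for binding affinity to corticotropin-releasing factor receptor 1 (Homo sapiens); a higher number here means a weaker inhibitor, a lower number a stronger inhibitor:
Compound 1 `CCCN(CCC)c1cc(C)nc2c(-c3ccc(Cl)cn3)c(C)nn12` gives 88 nM.
Compound 2 `CCCN(CCC)c1cc(C)nc2c(-c3ncc(NC)cc3C)c(C)nn12` gives 40 nM.
Compound 3 `CCCN(CCC)c1cc(C)nc2c(-c3ncc(N=O)cc3C)c(C)nn12` gives 100 nM.

Among these three numbers compound 1 stands second highest. The step of a 2.2-fold lower number from compound 1 to compound 2 (0.34 log units; beyond the scatter) goes beyond the scatter, whereas a 1.1-fold higher number from compound 1 to compound 3 (0.06 log units; within the scatter) stays within it.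

Compound 4 `CCCN(CCC)c1cc(C)nc2c(-c3ncccc3C)c(C)nn12` carries the change (3-methylpyridin-2-yl in place of 5-chloropyridin-2-yl on an aromatic carbon). Both measured steps away from compound 1 bring in the same methyl on the pyridine ring but also a further group, and they diverge: a 2.5-fold higher number from compound 2 to compound 3 (0.40 log units; beyond the scatter) shows that this further group decides the outcome. Compound 4 brings in the methyl alone, so no clear pull in either direction is indicated, and a step of a 1.1-fold higher number from compound 1 to compound 4 (0.06 log units; within the scatter) is expected. Compound 4 is therefore estimated at 100 nM, with a range from 45 nM to 230 nM.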

Compound 4, inhibition constant: 110 nM
The estimate for compound 4 lay 1.1-fold (0.04 log units) below the measured number; the measured number falls inside the stated range.
By their numbers in this assay, from the lowest: compound 2; then compounds 1, 3 and 4 (each within the scatter of the next).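

The methyl on the pyridine ring, without a further group, cannot be told apart from the 5-chloropyridin-2-yl ring (a 1.3-fold higher number from compound 1 to compound 4 (0.10 log units; within the scatter)). The further group therefore carries the difference: removing methylamino gives a step beyond the scatter (a 2.8-fold higher number from compound 2 to compound 4 (0.44 log units; beyond the scatter)), while removing the nitroso group does not (a 1.1-fold higher number from compound 3 to compound 4 (0.04 log units; within the scatter)). Nothing measured here explains why methylamino stands apart. Still open, from the compounds shown here alone, is whether ethylamino or a carboxylic acid in place of methylamino would lower the number further. Also open, going by these compounds, is whether methylamino gives a similar step on a pyridine ring without the methyl.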